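Trifluoromethoxy in place of trifluoromethyl: working notes

The source may hold more compounds than are shown below. What is called first, only, known or untested is meant among the compounds shown, and "the series" means these compounds.

In a functional assay on LNCaP cells (Homo sapiens) for antiproliferative activity, read by propidium iodide staining, with a stated time of 96 h (on this read-out lower numbers stand for stronger inhibition and higher numbers for weaker inhibition), compound 1 `CC(O)(CSc1ccc(C(F)(F)F)cc1)C(=O)Nc1ccc(S(F)(F)(F)(F)F)cc1` gives 17000 nM. Compound 2 `CC(O)(CSc1ccccc1C(F)(F)F)C(=O)Nc1ccc(S(F)(F)(F)(F)F)cc1` gives 12300 nM, and these two numbers lie within the scatter of each other. Compound 3 `CC(O)(CSc1ccccc1OC(F)(F)F)C(=O)Nc1ccc(S(F)(F)(F)(F)F)cc1` differs from compound 2 by one change: trifluoromethoxy in place of trifluoromethyl on an aromatic carbon. This is trifluoromethoxy in place of trifluoromethyl on an aromatic carbon, ortho to a large group.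

Among the compounds with values here, only one measured step is available, a 1.4-fold lower number from compound 1 to compound 2 (0.14 log units; within the scatter). Within the data shown here, it concerns the placement of trifluoromethyl, and no measured step exchanges trifluoromethyl for trifluoromethoxy, so its bearing is indirect. On this limited evidence, no step beyond the scatter is expected in this assay, and neither direction is favoured. The expected change is a 1.0-fold lower number from compound 2 to compound 3 (0.01 log units; within the scatter). For compound 3 the estimate is 12000 nM, with an estimated range of 6000 nM to 25000 nM.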

Compound 3, half-maximal inhibitory concentration: 10600 nM
Compound 3: middle estimate off by 1.1-fold (0.05 log units), on the high side; the measured number falls inside the stated range.
By their numbers in this assay, from the lowest: compounds 3, 2 and 1 (each within the scatter of the next).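

Trifluoromethoxy in place of trifluoromethyl on an aromatic carbon, ortho to a large group, now has a measured step in this assay, namely a 1.2-fold lower number from compound 2 to compound 3 (0.06 log units; within the scatter), and this step lies within the scatter. Within the data shown here, at this place, then, the exchange adds one oxygen and one hydrogen-bond acceptor to the substituent, yet compound 3 and compound 2 cannot be told apart on this read-out; the earlier compounds offered no measured step for this exchange. No measurement available here accounts for the two groups reading alike.

Going by these compounds, whether trifluoromethoxy reads the same at the place held by trifluoromethyl in compound 1 remains open. Also open, on these data alone, is whether an amine, a carboxylic acid or a nitrile ortho to the large group would give a step beyond the scatter.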